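Curcuminoid series on SW480: trimethoxyphenyl to fluorohydroxyphenyl

The compounds below may be only part of what the source reports. "The series", "measured", "known", "first", "only" and "open" are said of these compounds alone.

Measured so far:
compound 1 `COc1cccc(/C=C/C(=O)/C=C(O)/C=C/c2cccc(OC)c2OC)c1OC` gives 12100 nM
compound 2 `COc1cccc(/C=C/C(=O)C(=Cc2cc(OC)c(OC)c(OC)c2)C(=O)/C=C/c2cccc(OC)c2OC)c1OC` gives 650 nM

Both were run in a functional assay on SW480 cells (Homo sapiens) for antiproliferative activity, read by sulforhodamine B assay, with a stated time of 48 h; a higher number here means a weaker inhibitor, a lower number a stronger inhibitor. For the measured compounds named here, compound 2 stands at the lowest of the two numbers, and the only neighbour, compound 1, sits far above it, a gap beyond the usual scatter; the two structures differ in more than one place, so no single step between them is drawn, and the values are simply reported as they stand.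

The next compound, compound 3 `COc1cccc(/C=C/C(=O)C(=Cc2ccc(O)c(F)c2)C(=O)/C=C/c2cccc(OC)c2OC)c1OC`, follows from compound 2 by one change: 3-fluoro-4-hydroxyphenyl in place of 3,4,5-trimethoxyphenyl on a double-bonded chain carbon bound to a double-bonded chain carbon. The group that leaves carries three acceptors and no donor; the group that enters brings one donor and one acceptor, with a fluorine in place of the methoxy groups.

Going by the values given here, no measured step informs this change directly. Among the compounds with values here, the expectation is a moderate weakening, a step of a 2.3-fold higher number from compound 2 to compound 3 (0.36 log units; beyond the scatter) in this assay, since the only comparison on hand places compound 2 at 650 nM and nothing shows that a smaller substituted ring at this position holds that level. Compound 3 is estimated at 1500 nM, with a range from 500 nM to 5000 nM.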

Compound 3, half-maximal inhibitory concentration: 330 nM
Compound 3: middle estimate off by 4.5-fold (0.66 log units), on the high side; the measured number lies below the stated range.
By their numbers in this assay, from the lowest: compounds 3 and 2 (each within the scatter of the next); then compound 1.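

In this assay, 3-fluoro-4-hydroxyphenyl in place of 3,4,5-trimethoxyphenyl on a double-bonded chain carbon bound to a double-bonded chain carbon comes with a 2.0-fold lower number from compound 2 to compound 3 (0.29 log units; within the scatter), so compound 2 and compound 3 stand level. The level reached with compound 2 at this position therefore does not depend on the 3,4,5-trimethoxyphenyl group: a group with fewer heavy atoms, carrying a hydrogen-bond donor where the leaving group has none, and with fluorine in place of the methoxy groups, serves equally well in this assay. No measurement on hand accounts for this equivalence.

The fluorine and the hydroxyl enter in a single step, so the compounds shown do not separate what each of them means here, and a ring with only one of the two would be needed to tell them apart. On these data alone, how this position answers to groups of another kind, such as a carboxylic acid or an amine on the ring, or a saturated butyl chain in place of the ring, remains open.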